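The source may report more compounds than this note shows. Statements on the series, on what has been measured and on what is new or still open speak of the compounds shown alone.

Measured so far in a functional assay on RAW264.7 cells (Mus musculus) for inhibition, read by Griess assay, with stated times of 2 h and 24 h; on this read-out higher numbers stand for weaker inhibition and lower numbers for stronger inhibition:
compound 1 `COc1ccc([C@@H]2C/C(=N\O)c3c(O)cc(OCc4cn(Cc5ccccc5F)nn4)cc3O2)cc1O` gives 5710 nM
compound 2 `CCCn1cc(COc2cc(O)c3c(c2)O[C@H](c2ccc(OC)c(O)c2)C/C3=N\O)nn1` gives 2340 nM

Compound 2 holds the lowest of the two numbers shown; its nearest neighbour is compound 1, and the step between them is a 2.4-fold lower number from compound 1 to compound 2 (0.39 log units; beyond the scatter). For the measured compounds named here, that single step is the only one bearing on the change now under consideration, and it concerns the same place on the shared core: a saturated chain carbon bound to an aromatic nitrogen.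

Compound 3 `COc1ccc([C@@H]2C/C(=N\O)c3c(O)cc(OCc4cn(CC5CC5)nn4)cc3O2)cc1O` is not yet measured. It differs from compound 2 as follows: cyclopropyl in place of ethyl on a saturated chain carbon bound to an aromatic nitrogen. Going by the values given here, the one measured step swapped an aromatic ring for a short chain and gave a modest gain; the present change puts a small non-aromatic ring of three carbon atoms where the ethyl stood, and no measured pair speaks to that exchange. The expectation is therefore a step of no more than the usual scatter in either direction, with the number for compound 3 staying close to that of compound 2, as a 1.2-fold lower number from compound 2 to compound 3 (0.07 log units; within the scatter). Compound 3 is thus estimated at 2000 nM, within a range from 900 nM to 4500 nM.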

Compound 3, half-maximal inhibitory concentration: 6320 nM
Beside the measured number, compound 3's estimate is 3.2-fold (0.50 log units) below it; the whole stated range lies below it.
By their numbers in this assay, from the lowest: compound 2; then compounds 1 and 3 (each within the scatter of the next).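

In this assay this place on the shared core responds even to a small exchange among non-aromatic groups: cyclopropyl in place of ethyl on a saturated chain carbon bound to an aromatic nitrogen gives a 2.7-fold higher number from compound 2 to compound 3 (0.43 log units; beyond the scatter), so the propyl group of compound 2 cannot be swapped for cyclopropylmethyl without loss. The lower number seen on leaving the 2-fluorophenyl group therefore does not extend to every non-aromatic replacement, since cyclopropyl in place of 2-fluorophenyl gives only a 1.1-fold higher number from compound 1 to compound 3 (0.04 log units; within the scatter). Among these three compounds, compound 2 alone stands apart, while the 2-fluorophenyl and cyclopropyl groups cannot be told apart on this read-out.

Nothing available accounts for the difference between propyl and cyclopropylmethyl at this place. From the compounds shown here alone, it remains open whether butyl, a longer chain, a branched isopropyl group, a chain ending in an amine or one ending in a carboxylic acid would lower or raise the number, and so whether propyl is a narrow optimum or one point on a broader trend.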